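Trifluoroacetyl for Methyl on a Sub-Nanomolar Bad Ligand

The source may hold more compounds than are shown below. What is called first, only, known or untested is meant among the compounds shown, and "the series" means these compounds.

compound 1 `Cc1cc(S(=O)(=O)NC(=O)c2ccc(N3CCN(Cc4ccccc4-c4ccc(Cl)cc4)CC3)cc2)ccc1N[C@H](CCN(C)C)CSc1ccccc1` — < 1 nM
compound 2 `CN(C)CC[C@H](CSc1ccccc1)Nc1ccc(S(=O)(=O)NC(=O)c2ccc(N3CCN(CC4=C(c5ccc(Cl)cc5)CCCC4)CC3)cc2)cc1[N+](=O)[O-]` — < 1 nM

In an assay on isolated protein for displacement of a labelled ligand from Bcl2-associated agonist of cell death (Homo sapiens), read by fluorescence polarization (on this read-out higher numbers stand for weaker inhibition and lower numbers for stronger inhibition), compound 1 gives < 1 nM, which is a limit of the assay rather than a number. Compound 2 gives < 1 nM, again a limit. Both values rest at the limit of < 1 nM in this assay, at which 2 of the 2 values shown sit, so nothing separates the two compounds on this read-out.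

Compound 3 `CN(C)CC[C@H](CSc1ccccc1)Nc1ccc(S(=O)(=O)NC(=O)c2ccc(N3CCN(Cc4ccccc4-c4ccc(Cl)cc4)CC3)cc2)cc1C(=O)C(F)(F)F` differs from compound 1 by (trifluoromethyl)carbonyl in place of methyl on an aromatic carbon. Going by the values given here, no measured pair shows this change, so its size is unknown; compound 3 is expected to stay at or near the limit, with the step that the limit leaves unreadable from compound 1 to compound 3 expected to lie within the scatter. Compound 3 is estimated at 0.5 nM, from 0.1 nM to 3 nM.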

Compound 3, inhibition constant: < 1 nM
Compound 3: no number, only a limit; the forecaster's own chance of this, stated with the estimate: 70%; the middle value is on the limit's open side.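

No step from compound 1 to compound 3 can be read, because both values are limits rather than numbers: the limit of < 1 nM in this assay, at which 3 of the 3 values shown sit.

The compounds shown leave open what (trifluoromethyl)carbonyl in place of methyl does to the inhibition constant in this assay.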